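The compounds below may be only part of what the source reports. "The series", "measured", "known", "first", "only" and "open" are said of these compounds alone.

In an ADME assay on Huh7.5.1 cells (Homo sapiens) for cytotoxicity, read by WST assay, with a stated time of 48 h (a higher number here means that more compound is tolerated, a lower number that less compound is tolerated), compound 1 `Cc1c(-c2ccc(Cc3ccc(C(C)(C)C)cc3)cc2)[nH]c2cccc(F)c2c1=O` gives > 5000 nM, which is a limit of the assay and not a number. Compound 2 `Cc1c(-c2ccc(Cc3ccc(C(C)(O)C(F)(F)F)cc3)cc2)[nH]c2cccc(F)c2c1=O` gives > 2500 nM, which is also only a limit. Compound 3 `Cc1c(-c2ccc(Cc3ccc(C(O)C(F)(F)F)cc3)cc2)[nH]c2cccc(F)c2c1=O` differs from compound 2 by hydrogen in place of methyl on a saturated chain carbon bound to an aromatic carbon, an oxygen on a saturated carbon and a saturated chain carbon, turning 1-hydroxy-1-(trifluoromethyl)ethyl into 2,2,2-trifluoro-1-hydroxyethyl. For the measured compounds named here, the only measured step, a step that the two limits leave unreadable from compound 1 to compound 2, also involves 1-hydroxy-1-(trifluoromethyl)ethyl, but it offers no size to go on. No step beyond the usual scatter is therefore expected in this assay. The expected step is a step that the limit leaves unreadable from compound 2 to compound 3. Compound 3 is estimated at 4000 nM, with an expected range from 1800 nM to 9000 nM.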

Compound 3, half-maximal cytotoxic concentration: > 10000 nM
Compound 3: no number, only a limit; the forecaster's own chance of this, stated with the estimate: 75%; middle value at least 2.5-fold (0.39 log units) away from the limit.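

For the compounds shown here, compound 1, compound 2 and compound 3 each give only a limit in this assay, and no step among them can be read. On these data alone, the concentration at which each becomes cytotoxic, and whether swapping these groups shifts it, stays open.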